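This account rests on a few compounds, and the source may have more. Where it says the series, first, only, none or still open, it means among the compounds named here.

In an assay on isolated protein for binding affinity to Leucine-rich repeat serine/threonine-protein kinase 2 variant G2019S (Homo sapiens), read by TR-FRET and LanthaScreen, with a stated time of 2 h (a higher number here means a weaker inhibitor, a lower number a stronger inhibitor), compound 1 `CN(C)c1c(C#N)c2c(N)ncnc2n1C` gives 259 nM. Compound 2 `Cn1c(NCc2ccccc2)c(C#N)c2c(N)ncnc21` gives 243 nM in this assay. Of these two numbers, that of compound 1 is the larger, yet the gap between them lies within the usual scatter, so neither compound can be called the stronger inhibitor. Compound 3 `Cn1c(-c2ccccc2)c(C#N)c2c(N)ncnc21` has not been measured. It differs from compound 1 in one place: phenyl in place of dimethylamino on an aromatic carbon. Among the compounds with values here, with no measured step to lean on, the expected step from compound 1 to compound 3 is a 1.2-fold higher number from compound 1 to compound 3 (0.06 log units; within the scatter), in no clear direction beyond the scatter. Compound 3 is therefore estimated at 300 nM, with a range from 80 nM to 1200 nM.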

Compound 3, inhibition constant: 33 nM
Compound 3: middle estimate off by 9.1-fold (0.96 log units), on the high side, outside the stated range (below it).
By their numbers in this assay, from the lowest: compound 3; then compounds 2 and 1 (each within the scatter of the next).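

In this assay, within the data shown here, the swap of dimethylamino for phenyl on this aromatic carbon gives a 7.8-fold lower number from compound 1 to compound 3 (0.89 log units; beyond the scatter) and is the first change here to go beyond the scatter, so this position does respond to its substituent. A phenyl ring alone does not account for this: compound 2, whose benzylamino group also holds one, gives 243 nM and stays within the scatter of compound 1. Nothing available explains the gain.

Going by these compounds, whether a pyridine ring or a substituted phenyl here would go further remains open. So does whether a small methyl group would do as well as phenyl.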